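Imidazolyl for Pyrrolidinyl on Two Cores in Mouse Dosing

The source may report more compounds than this note shows. Statements on the series, on what has been measured and on what is new or still open speak of the compounds shown alone.

Measured compounds:
compound 1, `COC(=O)N(C)C(C)C#CCN1CCCC1`: 14.2 mg/kg
compound 2, `COC(=O)N(C)C(C)C#CCn1ccnc1`: 8 mg/kg
compound 3, `CC(C#CCN1CCCC1)N1CCN(C)C1=O`: > 30 mg/kg

The read-out throughout is a functional assay on the whole organism for agonist activity, with Mus musculus as the target; on this read-out lower numbers stand for an effect already at smaller amounts and higher numbers for an effect only at larger amounts of compound. Compound 1 gives 14.2 mg/kg in this assay. Compound 2 gives 8 mg/kg in this assay. Between them the structures differ in one place, (1H-imidazol-1-yl in place of pyrrolidin-1-yl on a saturated chain carbon bound to a triple-bonded carbon), and the step is a 1.8-fold lower number from compound 1 to compound 2 (0.25 log units; within the scatter). Compound 3 carries a different core; how its core differs from that of compound 1 is not broken down here. For compound 3 this assay reports only a limit, > 30 mg/kg, which is the limit of > 30 mg/kg in this assay, at which 1 of the 3 values shown sits.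

Compound 4, `CC(C#CCn1ccnc1)N1CCN(C)C1=O`, has not been measured in this assay. It differs from compound 3 by 1H-imidazol-1-yl in place of pyrrolidin-1-yl on a saturated chain carbon bound to a triple-bonded carbon, the same change that was made from compound 1 to compound 2, at the same kind of place. On the core of compound 1 that change gave a 1.8-fold lower number from compound 1 to compound 2 (0.25 log units; within the scatter), a step within the scatter. With nothing more than that step and the limit of compound 3 to go on, the step from compound 3 to compound 4 is expected to be of similar size, an at least 1.2-fold lower number from compound 3 to compound 4 (0.07 log units; that floor lies within the scatter). Compound 4 is therefore estimated at 25 mg/kg in this assay, with an expected range from 10 mg/kg to 60 mg/kg, and a fair chance that this assay again reports only a limit for compound 4.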

Compound 4, dose for half-maximal effect: > 100 mg/kg
Compound 4 ended at the assay's limit; the forecaster's own chance of this, stated with the estimate: 55%; middle value at least 4.0-fold (0.60 log units) away from the limit.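

In this assay compound 3 is reported only as a limit, > 30 mg/kg. Compound 4 is also reported only as a limit, > 100 mg/kg, so no step can be read between these two compounds. The compounds shown leave open how large the change from pyrrolidin-1-yl to 1H-imidazol-1-yl is on the core of compound 3, and whether it runs the same way as on the core of compound 1.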